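The compounds below may be only part of what the source reports. "The series", "measured", "known", "first", "only" and "open" are said of these compounds alone.

Measured compounds in a functional assay on MCF7 cells (Homo sapiens) for antiproliferative activity, read by MTT assay, with a stated time of 72 h; on this read-out lower numbers stand for stronger inhibition and higher numbers for weaker inhibition:

compound 1, `O=S1(=O)C=Cc2ccc(Nc3ccc(C(F)(F)F)cc3)cc21`, gives 1270 nM
compound 2, `COc1ccc(Nc2ccc3c(c2)S(=O)(=O)C=C3)cc1`, gives 1210 nM
compound 3, `COc1ccccc1Nc1cccc2c1S(=O)(=O)C=C2`, gives 5100 nM

Compound 1 and compound 2 share one core and differ by trifluoromethyl in place of methoxy on an aromatic carbon; in this assay that change gave a 1.0-fold higher number from compound 2 to compound 1 (0.02 log units; within the scatter), so the two numbers are not separated. Compound 3 has the same atoms as compound 2 joined differently; how the two cores differ is not broken down here. Compound 3 gives the highest number of the three, and its values beside those of compound 1 and compound 2 lie beyond the scatter in both cases, so on its own core compound 3 is the weaker inhibitor of this small set.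

Compound 4, `O=S1(=O)C=Cc2cccc(Nc3ccccc3C(F)(F)F)c21`, has the core of compound 3 and differs from it by trifluoromethyl in place of methoxy on an aromatic carbon. Among the compounds with values here, this is the same kind of change as the one from compound 2 to compound 1, though not the same: there the entering group sits para to a large group, here it sits ortho to a large group. Within the data shown here, the only measured instance of exchanging methoxy for trifluoromethyl on an aromatic carbon left the number essentially unchanged, and nothing in the set shows that the core of compound 3 responds differently. The step from compound 3 to compound 4 is therefore expected to be about a 1.0-fold lower number from compound 3 to compound 4 (0.01 log units; within the scatter), resting on a 1.0-fold higher number from compound 2 to compound 1 (0.02 log units; within the scatter), with extra width allowed for the altered surroundings of the group. Compound 4 is estimated to give 5000 nM, between 2300 nM and 11000 nM, in this assay.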

Compound 4, half-maximal inhibitory concentration: 8100 nM
Compound 4: middle estimate off by 1.6-fold (0.21 log units), on the low side, and the stated range covers the measured number.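

In this assay, exchanging methoxy for trifluoromethyl on an aromatic carbon of the core of compound 3 gives a 1.6-fold higher number from compound 3 to compound 4 (0.20 log units; within the scatter), and this step does not differ from the earlier one on the other core: the same change on two cores in this assay, a 1.0-fold higher number (0.02 log units; within the scatter) from compound 2 to compound 1 and a 1.6-fold higher number (0.20 log units; within the scatter) from compound 3 to compound 4, 1.5-fold (0.18 log units) apart, within the scatter of two such steps Within these two pairs, the change therefore carries from one core to the other, with neither step separating the two compounds involved. This does not show that the exchange is neutral across the series, as it rests on two pairs in a single assay, a small real difference between the cores could lie hidden within the scatter, and the core and the place of the group change together between the two pairs, so their contributions cannot be told apart.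

The compounds shown leave open whether the same result would hold for other groups at this place, such as chlorine, a nitrile, an amine or a carboxylic acid, and how any of these would compare with a plain hydrogen there. Within the data shown here, they also include no pair carrying one group at two different places on a single core, so the part played by the place of the group remains unresolved.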